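Cyclopentyl for methyl on a sulfur, at the limit

This account rests on a few compounds, and the source may have more. Where it says the series, first, only, none or still open, it means among the compounds named here.

In an ADME assay on HFF cells (Homo sapiens) for cytotoxicity, with a stated time of 8 days (a higher number here means that more compound is tolerated, a lower number that less compound is tolerated), compound 3 `CSc1nc(N)nc2c1ncn2/C=C1/CC1(CO)CO` reads > 300000 nM as a limit and not a number. Compound 1 `Nc1nc(NCc2ccccc2)c2ncn(/C=C3/CC3(CO)CO)c2n1` reads > 300000 nM as a limit too. Compound 2 `Nc1nc(N2CCCC2)c2ncn(/C=C3/CC3(CO)CO)c2n1` reads > 300000 nM as a limit too. Compound 3 thus stands at the limit of > 300000 nM in this assay, at which 3 of the 3 values shown sit, and has no number of its own. Compound 4 `Nc1nc(SC2CCCC2)c2ncn(/C=C3/CC3(CO)CO)c2n1` carries cyclopentyl in place of methyl on a sulfur. The measured steps that bear on this are a step that the two limits leave unreadable from compound 1 to compound 3 and a step that the two limits leave unreadable from compound 2 to compound 3 and a step that the two limits leave unreadable from compound 1 to compound 2 and none of them gives a size. The expected change in this assay is therefore none beyond the scatter (a number no higher from compound 3 to compound 4 (the limit leaves the size open)). Compound 4 is expected at 300000 nM (estimated range 100000 nM to 300000 nM).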

Compound 4, half-maximal cytotoxic concentration: > 300000 nM
Compound 4: a limit, no number (the forecaster's own chance of this, stated with the estimate: 75%); the middle value lies on the limit itself.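

Compound 4 gives only a limit, as do compound 1, compound 2 and compound 3, so none of the steps to compound 4 can be read. The compounds shown leave open whether cyclopentyl and methyl on a sulfur differ at all in this assay.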